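The compounds below may be only part of what the source reports. "The series", "measured", "known", "first", "only" and "open" are said of these compounds alone.

Measured so far:
Compound 1 is `Nc1ccccc1NC(=O)/C=C/c1cn([C@H]2C[C@@H](C(=O)O)N(Cc3ccccc3)C2)nn1`. In an assay on cells for inhibition of histone deacetylase 11 (Homo sapiens), read by fluorescence, with stated times of 3 h and 30 min, tested at 2 uM, in the presence of a further agent that is not named here (on this read-out higher numbers stand for more inhibition at the one concentration tested (going by the name of the read-out) and lower numbers for less inhibition), compound 1 gives < 10%, which is a limit of the assay and not a number.
Compound 2 is `Nc1ccccc1NC(=O)/C=C/c1cn([C@@H]2C[C@@H](C(=O)O)N(Cc3ccccc3)C2)nn1`. In this assay compound 2 gives < 10%, again a limit of the assay.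

Compound 2 therefore stands at the limit in this assay, with no number of its own. Among the measured compounds shown here, the single measured step, a step that the two limits leave unreadable from compound 1 to compound 2, cannot be sized because of the limit of < 10% in this assay, at which 2 of the 2 values shown sit. Compound 3 is `Nc1ccccc1NC(=O)/C=C/c1cn([C@H]2C[C@H](C(=O)O)N(Cc3ccccc3)C2)nn1`. Its change from compound 2: the two compounds have the same atoms and bonds and differ only in configuration as drawn: 2 of 3 stereo elements differ; a stereocentre at a saturated ring carbon is drawn R in compound 2 and S in compound 3; a stereocentre at a saturated ring carbon is drawn S in compound 2 and R in compound 3. The measured step bears on this change because of the fact that compounds 1 and 2 differ only in the configuration as drawn, but it supplies no readable size. No step beyond the scatter is expected in this assay in either direction, and a further limit is the likelier outcome. For compound 3 the estimate in this assay is 5%, expected to fall between 0% and 15%. The expected step that the limit leaves unreadable from compound 2 to compound 3 is taken as essentially none.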

Compound 3, a percentage reported as inhibition, at one concentration (the size of the read-out at that concentration, not a potency): < 10%
Compound 3: a limit, no number; the forecaster's own chance of this, stated with the estimate: 70%; the middle value lies beyond the limit too.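

No new step can be read among compound 1, compound 2 and compound 3 in this assay, as all three stand at one limit of the assay, which is not a number: the limit of < 10% in this assay, at which 3 of the 3 values shown sit.

These compounds leave open whether the configuration drawn at either saturated ring carbon makes any difference to inhibition in this assay.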